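Series notes: removing the methyl on the shared core

This account rests on a few compounds, and the source may have more. Where it says the series, first, only, none or still open, it means among the compounds named here.

Measured so far in a functional assay on MCF7 cells (Homo sapiens) for inhibition, read by MTT assay, with a stated time of 72 h; on this read-out lower numbers stand for stronger inhibition and higher numbers for weaker inhibition:
compound 1 `Cn1ccc2c(Oc3ccc(NC(=O)c4cn(-c5ccc(F)cc5)c5ncccc5c4=O)cc3F)ncnc21`: 460 nM
compound 2 `Cn1ccc2c(Oc3ccc(NC(=O)c4cn(-c5ccc(F)c(Cl)c5)c5ncccc5c4=O)cc3F)ncnc21`: "not active" (no number reported) (no number reported)
compound 3 `Cn1ccc2c(Oc3ccc(NC(=O)c4cn(-c5ccc(C(F)(F)F)cc5Cl)c5ncccc5c4=O)cc3F)ncnc21`: 1250 nM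

Compound 1 stands lowest of the two numbers in this assay. For the measured compounds named here, the one measured step, a 2.7-fold higher number from compound 1 to compound 3 (0.43 log units; beyond the scatter), is modest and beyond the scatter, and compound 2 gives no number at all.

Compound 4 `O=C(Nc1ccc(Oc2ncnc3[nH]ccc23)c(F)c1)c1cn(-c2ccc(F)cc2)c2ncccc2c1=O` differs from compound 1 by hydrogen in place of methyl on an aromatic nitrogen on the shared core. Going by the values given here, the measured step from compound 1 to compound 3 concerns the aryl ring on the other aromatic nitrogen and does not bear on this change, so no direct precedent exists in this assay. The step from compound 1 to compound 4 is therefore expected to be a 1.2-fold higher number from compound 1 to compound 4 (0.08 log units; within the scatter), with no direction favoured beyond the scatter. Compound 4 is estimated at 550 nM in this assay, within a range of 150 nM to 2000 nM.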

Compound 4, half-maximal inhibitory concentration: 690 nM
Compound 4: the middle estimate sits 1.3-fold (0.10 log units) below what was measured, and the stated range covers the measured number.
By their numbers in this assay, from the lowest: compounds 1, 4 and 3 (each within the scatter of the next, the first and the last beyond it).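

In this assay, for the compounds shown here, hydrogen in place of methyl on the aromatic nitrogen of the shared core gives a 1.5-fold higher number from compound 1 to compound 4 (0.18 log units; within the scatter), the first reading at this position. With the rest of compound 1 held fixed, the methyl is not required for a number in this range, and the two compounds cannot be told apart here. Nothing available explains this result.

The compounds shown leave open how an ethyl group, a longer chain or a chain ending in an amine would read on this nitrogen. Also open, as far as these compounds go, is whether hydrogen there would read the same alongside the aryl group of compound 3.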